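The source may hold more compounds than are shown below. What is called first, only, known or untested is meant among the compounds shown, and "the series" means these compounds.

Compounds measured in a functional assay on HCT-116 cells (Homo sapiens) for antiproliferative activity, read by sulforhodamine B assay, with a stated time of 72 h; a higher number here means a weaker inhibitor, a lower number a stronger inhibitor: compound 1 `COc1ncc(-c2ccc3ncnc(Nc4ccc(OCCO)cc4)c3c2)cc1NS(=O)(=O)c1ccc(F)cc1F` at 1060 nM; compound 2 `CCCCS(=O)(=O)Nc1cc(-c2ccc3ncnc(Nc4ccc(OCCO)nc4)c3c2)cnc1OC` at > 20000 nM; compound 3 `COc1ncc(-c2ccc3ncnc(Nc4ccc(OCCO)c(Cl)c4)c3c2)cc1NS(=O)(=O)c1ccc(F)cc1F` at 7320 nM.

Compound 3 stands at the highest of the two numbers given in this assay; its nearest neighbour is compound 1, and the step of a 6.9-fold higher number from compound 1 to compound 3 (0.84 log units; beyond the scatter) places compound 3 well beyond the scatter from compound 1. For compound 2 the assay gives only a limit, (the limit of > 20000 nM in this assay, at which 1 of the 3 values shown sits), not a number.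

Compound 4 `COc1ncc(-c2ccc3ncnc(Nc4ccc(OCCO)nc4)c3c2)cc1NS(=O)(=O)c1ccc(F)cc1F` arises from compound 3 by the change (6-(2-hydroxyethoxy)pyridin-3-yl in place of 3-chloro-4-(2-hydroxyethoxy)phenyl on a nitrogen on an aromatic ring). Among the compounds with values here, only one measured step touches this region of the molecule: a 6.9-fold higher number from compound 1 to compound 3 (0.84 log units; beyond the scatter), which shows that adding the chloro group weakened inhibition considerably. Within the data shown here, compound 4 removes that chloro group again, and at the same time introduces a ring nitrogen; compound 2 carries the same 6-(2-hydroxyethoxy)pyridin-3-yl group but a different sulfonamide, so it offers no direct step. The expectation is therefore that compound 4 recovers part of the loss seen in compound 3, a step of a 2.4-fold lower number from compound 3 to compound 4 (0.39 log units; beyond the scatter) toward a lower number. Compound 4 is estimated at 3000 nM, in a range from 800 nM to 12000 nM.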

Compound 4, half-maximal inhibitory concentration: 2340 nM
The estimate for compound 4 lay 1.3-fold (0.11 log units) above the measured number; the range from low to high includes it.
By their numbers in this assay, from the lowest: compound 1; then compound 4; then compound 3. At a limit, above all of these: compound 2.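

In this assay, the 6-(2-hydroxyethoxy)pyridin-3-yl group on the nitrogen can be set against both phenyl groups at this position, giving a 2.2-fold higher number from compound 1 to compound 4 (0.34 log units; beyond the scatter) and a 3.1-fold lower number from compound 3 to compound 4 (0.50 log units; beyond the scatter). Compound 4 therefore falls between compound 1 and compound 3, so at this position the ring nitrogen gives a weaker inhibitor than the unsubstituted 4-(2-hydroxyethoxy)phenyl group, yet a stronger one than the 3-chloro-4-(2-hydroxyethoxy)phenyl group. With the pyridinyl group held constant, the group on the sulfonyl sulfur also proves to matter, as 2,4-difluorophenyl in place of butyl gives an at least 8.5-fold lower number from compound 2 to compound 4 (0.93 log units; beyond the scatter), a step that rests on a limit for compound 2: the limit of > 20000 nM in this assay, at which 1 of the 4 values shown sits.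

The compounds shown leave open whether the 2-hydroxyethoxy chain on this ring could be replaced by a longer chain, a carboxylic acid or an amine with the same result, and whether a chloro group on the pyridine ring would weaken inhibition as it does on the phenyl ring. They also leave open how a small methyl group on the sulfonyl sulfur would compare with butyl and 2,4-difluorophenyl.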